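Working notes: aryl variation, step from compound 3 to compound 4

The source may report more compounds than this note shows. Statements on the series, on what has been measured and on what is new or still open speak of the compounds shown alone.

Measured so far:
compound 1 `OC(CCn1nc2c(Br)c(Br)c(Br)c(Br)c2n1)c1cccc(Br)c1` — 54%
compound 2 `OC(CCn1nc2c(Br)c(Br)c(Br)c(Br)c2n1)c1ccc(F)cc1` — 46%
compound 3 `COc1cccc(C(O)CCn2nc3c(Br)c(Br)c(Br)c(Br)c3n2)c1` — 58%

Among the compounds with values here, in a functional assay on CCRF-CEM cells (Homo sapiens) for antiproliferative activity, read by MTT assay, with a stated time of 24 h, tested at 50 uM (on this read-out lower numbers stand for a stronger effect and higher numbers for a weaker effect at the one concentration tested), compound 3 gives the highest of the three numbers; it lies within the scatter of compound 1, as a number 4 percentage points higher from compound 1 to compound 3 (within the scatter) shows, and a number 12 percentage points higher from compound 2 to compound 3 (beyond the scatter) is the only step that goes beyond it. Compound 4 `OC(CCn1nc2c(Br)c(Br)c(Br)c(Br)c2n1)c1cccc(Cl)c1` is not yet measured. The change from compound 3 is chloro in place of methoxy on an aromatic carbon. Within the data shown here, the one step that bears on it is a number 4 percentage points higher from compound 1 to compound 3 (within the scatter), where bromo stood on that same aromatic carbon, and it stayed within the scatter. Swapping back to a halogen is therefore expected to give no step beyond the scatter, estimated as a number 3 percentage points lower from compound 3 to compound 4 (within the scatter). For compound 4 the expected value is 55%, with a range from 44% to 66%.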

Compound 4, a percentage reported as activity, at one concentration (the size of the read-out at that concentration, not a potency): 71%
The estimate for compound 4 lay 16 percentage points below the measured number; measured number outside the range, above it.
By their numbers in this assay, from the lowest: compounds 2, 1 and 3 (each within the scatter of the next, the first and the last beyond it); then compound 4.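

At this aromatic carbon the identity of the halogen matters in this assay, since chloro in place of bromo gives a number 17 percentage points higher from compound 1 to compound 4 (beyond the scatter), whereas methoxy in place of bromo had stayed within the scatter. Chloro in place of methoxy gives a number 13 percentage points higher from compound 3 to compound 4 (beyond the scatter) and 3-chlorophenyl in place of 4-fluorophenyl gives a number 25 percentage points higher from compound 2 to compound 4 (beyond the scatter), which leaves compound 4 with the weakest effect of the four at the one concentration tested. Nothing measured accounts for this sensitivity.

Going by these compounds, whether it is specific to chloro remains open, as does the outcome with an amine or a carboxylic acid on this same aromatic carbon.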